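This account rests on a few compounds, and the source may have more. Where it says the series, first, only, none or still open, it means among the compounds named here.

Compound 1: `CC(=O)OC[C@H]1O[C@@H](n2cnc3c(-c4ccccc4)ncnc32)[C@H](OC(C)=O)[C@@H]1OC(C)=O`, 10500 nM
Compound 2: `OC[C@H]1OC(n2cnc3c(-c4ccc(F)c(F)c4)ncnc32)[C@H](O)[C@@H]1O`, 1400 nM
Compound 3: `CC(=O)OC[C@H]1O[C@@H](n2cnc3c(-c4ccc(Cl)cc4)ncnc32)[C@H](OC(C)=O)[C@@H]1OC(C)=O`, 4300 nM

Of the compounds shown here, three have been measured in a functional assay on CCRF-CEM cells (Homo sapiens) for inhibition; a lower number here means a stronger inhibitor, a higher number a weaker inhibitor. Compound 2 has the lowest number of the three; its nearest neighbour is compound 3, a higher number by a clear margin, and compound 1 stands furthest away. Among the measured compounds shown here, the one measured step that joins two compounds differing in a single place is a 2.4-fold lower number from compound 1 to compound 3 (0.39 log units; beyond the scatter), a change on the acetylated series.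

Compound 4, `OC[C@H]1OC(n2cnc3c(-c4ccc(F)cc4)ncnc32)[C@H](O)[C@@H]1O`, has not yet been measured. It differs from compound 2 by hydrogen in place of fluoro on an aromatic carbon. For the measured compounds named here, no measured pair shows this change: the only single-place step on record, from compound 1 to compound 3, concerns a chloro group entering at a different position and on a different sugar, so it bears on the new step only loosely, suggesting that a single halogen on the phenyl ring can move the number by a modest amount. Removing one fluoro from compound 2 is therefore expected to cost little or nothing beyond the scatter, with a slight lean towards a higher number. Compound 4 is estimated to give 2500 nM in this assay, within a range of 1000 nM to 6500 nM, so that the expected step is a 1.8-fold higher number from compound 2 to compound 4 (0.25 log units; within the scatter).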

Compound 4, half-maximal inhibitory concentration: 750 nM
Beside the measured number, compound 4's estimate is 3.3-fold (0.52 log units) above it, outside the stated range (below it).
By their numbers in this assay, from the lowest: compounds 4 and 2 (each within the scatter of the next); then compound 3; then compound 1.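

In this assay, taking the fluoro group off an aromatic carbon, ortho to a fluoro group and meta to a large group, gives a 1.9-fold lower number from compound 2 to compound 4 (0.27 log units; within the scatter), so the two compounds cannot be told apart here. Among the compounds shown here, this is the first measured change at this place, and it shows that, with the remaining fluoro group and the free hydroxyl groups on the sugar in place, 3,4-difluorophenyl and 4-fluorophenyl serve equally well in this read-out: the number does not depend on having a fluoro group rather than hydrogen at this position. Nothing available accounts for this result, and the structures alone cannot supply a reason.

The compounds shown leave open whether a larger group at this place, such as methoxy or an amine, would keep the number within the scatter of these two compounds. They also leave open whether the same swap of fluoro for hydrogen reads alike on the acetylated compounds, and what the phenyl ring would give on the hydroxyl-bearing sugar with no fluoro group at all.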